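A few compounds are considered here, and "the series" means these few. Any claim that something is new, unique, unknown or untested is made for them only; others in the source may bear on it.

Compound 1 `O=C1C(Nc2ccccc2)=CC(=O)c2ncncc21` gives < 0.01 ug/mL in a functional assay on SK-OV-3 cells (Homo sapiens) for cytotoxicity, read by MTT assay, with a stated time of 72 h; on this read-out higher numbers stand for weaker inhibition and lower numbers for stronger inhibition.
Compound 2 `CCOc1ccc(NC2=CC(=O)c3ncncc3C2=O)cc1` gives 0.02 ug/mL.
Compound 3 `Cc1ccc(NC2=CC(=O)c3ncncc3C2=O)cc1` gives 0.03 ug/mL.

For compound 1 the reported value is a limit of the assay, not a measured number, so its standing is known only through (the limit of < 0.01 ug/mL in this assay, at which 1 of the 3 values shown sits). Compound 4 `O=C1C(Nc2ccc(Br)cc2)=CC(=O)c2ncncc21` differs from compound 1 by bromo in place of hydrogen on an aromatic carbon. Within the data shown here, two measured steps bear on this change, each exchanging a hydrogen of compound 1 for a small substituent: the ethoxy step gave an at least 2.0-fold higher number from compound 1 to compound 2 (0.30 log units; that floor lies within the scatter), and the methyl step gave an at least 3.0-fold higher number from compound 1 to compound 3 (0.47 log units; beyond the scatter). Both entering groups raised the number, so a modest rise is expected for bromo as well. Compound 4 is therefore estimated at 0.02 ug/mL (range 0.008 ug/mL to 0.05 ug/mL), an expected step of an at least 2.0-fold higher number from compound 1 to compound 4 (0.30 log units; that floor lies within the scatter).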

Compound 4, half-maximal inhibitory concentration: 0.02 ug/mL
The estimate for compound 4 equals the measured number at the digits printed; low and high end bracket the measured number.
By their numbers in this assay, from the lowest: compounds 2, 4 and 3 (each within the scatter of the next). At a limit, below all of these: compound 1.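

With bromo, a single heavy atom on the aromatic carbon para to a large group, the result is an at least 2.0-fold higher number from compound 1 to compound 4 (0.30 log units; that floor lies within the scatter). Among the substituted compounds, bromo is not distinguishable from the other two groups: there is a 1.5-fold lower number from compound 3 to compound 4 (0.18 log units; within the scatter), and no change at the digits printed from compound 2 to compound 4 (within the scatter). Compound 1 is known only as a limit, so the true size of any step away from hydrogen stays unknown: the limit of < 0.01 ug/mL in this assay, at which 1 of the 4 values shown sits.

On these data alone, whether an amine or a carboxylic acid on this carbon would fall in the same narrow band remains open. So does the effect of a longer chain there.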